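Swapping the anilide ring for a pyrimidine on compound 1

This account rests on a few compounds, and the source may have more. Where it says the series, first, only, none or still open, it means among the compounds named here.

Measured so far in a functional assay on cells for antagonist activity at D(4) dopamine receptor (Homo sapiens), read by TR-FRET and cAMP accumulation, with a stated time of 30 min; on this read-out higher numbers stand for weaker inhibition and lower numbers for stronger inhibition:
compound 1 `Cc1cccc(NC(=O)CN2CCN(c3ccc(Cl)cn3)CC2)c1` — 4700 nM
compound 2 `Cc1cccc(NC(=O)CN2CCN(c3ncccn3)CC2)c1` — 463 nM
compound 3 `Cc1cccc(NC(=O)CN2CCN(c3ccccn3)CC2)c1` — 82.7 nM

Compound 1 gives the highest number of the three in this assay, with compound 2 nearest a 10-fold lower number from compound 1 to compound 2 (1.01 log units; beyond the scatter) and compound 3 furthest a 57-fold lower number from compound 1 to compound 3 (1.75 log units; beyond the scatter); compound 2 to compound 3 is a 5.6-fold lower number from compound 2 to compound 3 (0.75 log units; beyond the scatter). Compound 4 `O=C(CN1CCN(c2ccc(Cl)cn2)CC1)Nc1cncnc1` differs from compound 1 at the other end of the shared core: pyrimidin-5-yl in place of 3-methylphenyl on an amide-type nitrogen. Among the measured compounds shown here, none of the measured steps touches the amide-type nitrogen, so they do not bear on this change; each of them alters the ring on the amine nitrogen in a ring. With no guide, compound 4 is expected to stay near compound 1 or drift to a weaker number, a 1.7-fold higher number from compound 1 to compound 4 (0.23 log units; within the scatter), giving an estimate of 8000 nM (range 2000 nM to 30000 nM).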

Compound 4, half-maximal inhibitory concentration: > 100000 nM
Compound 4: a limit, no number; the forecaster's own chance of this, stated with the estimate: 25%; middle value at least 12-fold (1.09 log units) away from the limit.
By their numbers in this assay, from the lowest: compound 3; then compound 2; then compound 1. At a limit, above all of these: compound 4.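

Among the compounds shown here, the amide-type nitrogen proves to be a position that matters in this assay, which the earlier steps, all on the ring on the amine nitrogen, could not show: pyrimidin-5-yl in place of 3-methylphenyl gives an at least 21-fold higher number from compound 1 to compound 4 (1.32 log units; beyond the scatter). Compound 4 gives a limit of the assay and not a number: the limit of > 100000 nM in this assay, at which 1 of the 4 values shown sits.

The compounds shown leave open whether this step follows the loss of the methyl or the ring nitrogens of the pyrimidine. Going by these compounds, an unsubstituted phenyl or a pyridin-3-yl on the amide-type nitrogen would separate the two, and the same change on compound 3 remains open as well.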